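Halogen swap on the pyrazoline aryl of a thiazole series

This account rests on a few compounds, and the source may have more. Where it says the series, first, only, none or still open, it means among the compounds named here.

Measured compounds:
compound 1 `COc1ccc(-c2csc(N3N=C(c4ccc(F)cc4)CC3c3ccc4c(c3)OCCO4)n2)cc1` — 4530 nM
compound 2 `Fc1ccc(C2=NN(c3nc(-c4ccc(Br)cc4)cs3)C(c3ccc4c(c3)OCCO4)C2)cc1` — 4200 nM

In a functional assay on MCF7 cells (Homo sapiens) for antiproliferative activity, read by MTT assay, with a stated time of 48 h (a higher number here means a weaker inhibitor, a lower number a stronger inhibitor), compound 1 stands at the higher of the two numbers, with compound 2 close by; the step of a 1.1-fold lower number from compound 1 to compound 2 (0.03 log units; within the scatter) is within the scatter. Compound 3 `COc1ccc(-c2csc(N3N=C(c4ccc(Br)cc4)CC3c3ccc4c(c3)OCCO4)n2)cc1` differs from compound 1 by bromo in place of fluoro on an aromatic carbon. Among the measured compounds shown here, the only measured step changes a different aryl group, and it was flat, so it gives no reason to expect movement here. Compound 3 is therefore expected to stay near compound 1, a step of a 1.1-fold lower number from compound 1 to compound 3 (0.03 log units; within the scatter), with an estimated value of 4200 nM in a range from 2000 nM to 9000 nM.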

Compound 3, half-maximal inhibitory concentration: 870 nM
The estimate for compound 3 lay 4.8-fold (0.68 log units) above the measured number; the whole stated range lies above it.
By their numbers in this assay, from the lowest: compound 3; then compounds 2 and 1 (each within the scatter of the next).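

This position responds to a single halogen exchange: in this assay, going from 4-fluorophenyl to 4-bromophenyl gives a 5.2-fold lower number from compound 1 to compound 3 (0.72 log units; beyond the scatter). The earlier change on the other aryl group gave only a 1.1-fold lower number from compound 1 to compound 2 (0.03 log units; within the scatter), so the two aryl groups do not behave alike in this small set. Nothing available here explains the difference. From the compounds shown here alone, whether the lower number is specific to bromo remains open, since chloro, methyl or an amine at this position could fall closer to either compound 1 or compound 3.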